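This account rests on a few compounds, and the source may have more. Where it says the series, first, only, none or still open, it means among the compounds named here.

Three aryl sulfonate esters were measured in a functional assay on HT-29 cells (Homo sapiens) for antiproliferative activity, read by sulforhodamine B assay, with a stated time of 48 h; a higher number here means a weaker inhibitor, a lower number a stronger inhibitor. Compound 1 `CCCCCC(=O)Nc1cccc(S(=O)(=O)Oc2ccccc2C(C)C)c1` gives 19000 nM, compound 2 `CCCCCC(=O)Nc1ccc(S(=O)(=O)Oc2ccccc2I)cc1` gives 13000 nM, and compound 3 `CC(C)c1ccccc1OS(=O)(=O)c1ccc(NC(=O)CCCCl)cc1` gives 6200 nM. Compound 2 therefore holds the second-highest of the three numbers; its value and that of compound 1 lie within the scatter of each other, while compound 3 stands clearly lower, beyond the scatter. Compound 4 `CCCCCNC(=O)Nc1ccc(S(=O)(=O)Oc2ccccc2I)cc1` has not yet been measured. It differs from compound 2 in one place: pentylamino in place of pentyl on a carbonyl carbon. Among the measured compounds shown here, no measured pair shows this change, so nothing indicates its direction, and no step beyond the scatter is expected. Compound 4 is estimated to give 11000 nM in this assay, with a range from 3500 nM to 35000 nM. The expected step is a 1.2-fold lower number from compound 2 to compound 4 (0.07 log units; within the scatter).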

Compound 4, half-maximal inhibitory concentration: 6600 nM
Compound 4: middle estimate off by 1.7-fold (0.22 log units), on the high side; the range from low to high includes it.
By their numbers in this assay, from the lowest: compounds 3, 4, 2 and 1 (each within the scatter of the next, the first and the last beyond it).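

In this assay, among the compounds shown here, this is the first direct reading of the change at this carbonyl carbon: pentylamino in place of pentyl gives a 2.0-fold lower number from compound 2 to compound 4 (0.29 log units; within the scatter), so the added nitrogen and its hydrogen-bond donor produce no step beyond the scatter. The pentylcarbamoyl form is thus tolerated here, with no clear gain or loss. Nothing measured offers an explanation for this result. Going by these compounds, whether a shorter chain, a longer chain or a cyclohexylamino group in place of pentylamino would move the number beyond the scatter remains open.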